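The compounds below may be only part of what the source reports. "The series", "measured", "known", "first", "only" and "open" are said of these compounds alone.

Compound 2 `O=C(O)Cc1sc(C(c2ccc(F)cc2)c2ccc(F)cc2)nc1-c1cc(F)cc(F)c1` gives 340 nM in an in vitro functional assay on HEK285-7 cells for antagonist activity at prostaglandin D2 receptor 2 (Homo sapiens), read by BRET and beta-arrestin recruitment; on this read-out higher numbers stand for weaker inhibition and lower numbers for stronger inhibition; compound 1 `N#Cc1cc(-c2nc(C(c3ccc(F)cc3)c3ccc(F)cc3)sc2CC(=O)O)ccc1F` gives 520 nM in this assay, and the two lie within the scatter of each other. Among the measured compounds shown here, the one measured step, a 1.5-fold lower number from compound 1 to compound 2 (0.18 log units; within the scatter), changed the aryl group at the same position and moved the number only within the scatter. Compound 3 `O=C(O)Cc1sc(C(c2ccc(F)cc2)c2ccc(F)cc2)nc1-c1ccnc(N2CCC2)c1` is not yet measured; it differs from compound 2 by 2-(azetidin-1-yl)pyridin-4-yl in place of 3,5-difluorophenyl on an aromatic carbon. For the measured compounds named here, the only precedent at this position is the small step of a 1.5-fold lower number from compound 1 to compound 2 (0.18 log units; within the scatter), so compound 3 is expected to change by about a 1.3-fold higher number from compound 2 to compound 3 (0.12 log units; within the scatter), with no clear direction. Compound 3 is thus estimated at 450 nM, between 150 nM and 1400 nM.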

Compound 3, half-maximal inhibitory concentration: > 100000 nM
Compound 3: a limit, no number; the forecaster's own chance of this, stated with the estimate: 3%; middle value at least 220-fold (2.34 log units) from the limit.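

The position next to the ring nitrogen does not accept every aryl group: 2-(azetidin-1-yl)pyridin-4-yl in place of 3,5-difluorophenyl gives an at least 290-fold higher number from compound 2 to compound 3 (2.46 log units; beyond the scatter), and in place of 3-cyano-4-fluorophenyl it gives an at least 190-fold higher number from compound 1 to compound 3 (2.28 log units; beyond the scatter). The exchange between the two fluorinated phenyl groups therefore gave no measure of how far this position can be varied. Compound 3 reads only as a limit of the assay, not a number: the limit of > 100000 nM in this assay, at which 1 of the 3 values shown sits.

The compounds shown do not separate the contribution of the azetidin-1-yl group from that of the pyridin-4-yl group. An unsubstituted pyridin-4-yl group and a 3-(azetidin-1-yl)phenyl group at this position would address that.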